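The compounds below may be only part of what the source reports. "The series", "measured", "known", "first", "only" and "open" are said of these compounds alone.

In a functional assay on HL-60 cells (Homo sapiens) for inhibition, with a stated time of 72 h (on this read-out higher numbers stand for weaker inhibition and lower numbers for stronger inhibition), compound 1 `OC[C@H]1O[C@@H](n2cnc3c(CSCc4ccccc4)ncnc32)[C@H](O)[C@@H]1O` gives 10700 nM and compound 2 `CSCc1ncnc2c1ncn2[C@@H]1O[C@H](CO)[C@@H](O)[C@H]1O` gives 13400 nM in the same range. Compound 3 `CN(Cc1ccccc1)Cc1ncnc2c1ncn2[C@@H]1O[C@H](CO)[C@@H](O)[C@H]1O` differs from compound 2 by benzyl(methyl)amino in place of methylsulfanyl on a saturated chain carbon bound to an aromatic carbon with the change on a saturated chain carbon bound to an aromatic carbon. For the measured compounds named here, the only measured step, hydrogen in place of phenyl on a saturated chain carbon bound to a sulfur, is a 1.3-fold higher number from compound 1 to compound 2 (0.10 log units; within the scatter) and bears on this change only in part. No step beyond the scatter is therefore expected in this assay in either direction. The expected change is a 1.1-fold lower number from compound 2 to compound 3 (0.05 log units; within the scatter) on this estimate. For compound 3 the estimated value is 12000 nM with a range from 4000 nM to 40000 nM as expected bounds.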

Compound 3, half-maximal inhibitory concentration: 5600 nM
Compound 3: middle estimate off by 2.1-fold (0.33 log units), on the high side; measured number inside the range.
By their numbers in this assay, from the lowest: compounds 3, 1 and 2 (each within the scatter of the next, the first and the last beyond it).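

In this assay, the saturated chain carbon bound to an aromatic carbon responds to a change of group: a 2.4-fold lower number from compound 2 to compound 3 (0.38 log units; beyond the scatter) comes with benzyl(methyl)amino in place of methylsulfanyl. Against benzylsulfanyl the result is weaker, with a 1.9-fold lower number from compound 1 to compound 3 (0.28 log units; within the scatter) for the same amino group, so the gain beyond the scatter holds only against methylsulfanyl. No measurement on hand accounts for this step.

On these data alone, whether the benzyl or the methyl on the nitrogen matters remains open. A simple dimethylamino group or a benzylamino group at this carbon would separate the two.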